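Indolyl Replacement at the Biaryl Terminus: Cytotoxicity Outlook

The compounds below may be only part of what the source reports. "The series", "measured", "known", "first", "only" and "open" are said of these compounds alone.

Compound 2 `CC(C)N(Cc1cccc(OCCCCCC(=O)O)c1)C(=O)c1ccc(-c2cccc(OC(F)(F)F)c2)cc1` carries the shared core with a 3-(trifluoromethoxy)phenyl group at the end of the biaryl. In an ADME assay on HepG2 cells (Homo sapiens) for cytotoxicity, read by CellTiter-Glo and resazurin assay, with a stated time of 72 h (on this read-out lower numbers stand for an effect already at smaller amounts and higher numbers for an effect only at larger amounts of compound), compound 2 gives > 26000 nM, which is a limit of the assay and not a number. Its closest neighbour, compound 1 `CC(C)N(Cc1cccc(OCCCCCC(=O)O)c1)C(=O)c1ccc(-c2cccc(N(C)C)c2)cc1`, differs only by dimethylamino in place of trifluoromethoxy on an aromatic carbon. In this assay compound 1 gives > 26000 nM, again a limit rather than a number. The step that the two limits leave unreadable from compound 1 to compound 2 is unreadable, since both values sit at the limit of > 26000 nM in this assay, at which 2 of the 2 values shown sit.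

Compound 3 `CC(C)N(Cc1cccc(OCCCCCC(=O)O)c1)C(=O)c1ccc(-c2c[nH]c3ccccc23)cc1` has not yet been measured; it differs from compound 2 by 1H-indol-3-yl in place of 3-(trifluoromethoxy)phenyl on an aromatic carbon. For the measured compounds named here, no measured step bears directly on this change, and the single measured step cannot be sized at all, so nothing in the two values argues for either direction. With both neighbours at the limit, compound 3 is estimated to give about 30000 nM in this assay, with a range from 10000 nM to 100000 nM. That estimate is expected to correspond to a step that the limit leaves unreadable from compound 2 to compound 3, most likely reported once more only as a limit.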

Compound 3, half-maximal effective concentration: > 26000 nM
Compound 3 ended at the assay's limit; the forecaster's own chance of this, stated with the estimate: 75%; the middle value does not contradict the limit.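

In this assay compound 3 gives > 26000 nM as a limit of the assay and not a number. No new step can be read from compound 1 or compound 2 to compound 3, because all three sit at the same limit: the limit of > 26000 nM in this assay, at which 3 of the 3 values shown sit. The compounds shown leave open how far apart the three lie and at what concentration any of them reaches a half-maximal effect.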